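A few compounds are considered here, and "the series" means these few. Any claim that something is new, unique, unknown or untested is made for them only; others in the source may bear on it.

Measured so far in a functional assay on A549 cells (Homo sapiens) for cytotoxicity, read by MTT assay, with a stated time of 48 h; on this read-out higher numbers stand for weaker inhibition and lower numbers for stronger inhibition:

- Compound 1 `COc1c(OCc2nc3ccccc3[nH]2)cc(O)c2c(=O)cc(-c3ccccc3)oc12`: > 100000 nM (a limit)
- Compound 2 `CCN(CC)CCCCOc1cc(O)c2c(=O)cc(-c3ccccc3)oc2c1OC`: 1000 nM

Within the data shown here, compound 2 holds the only actual number in this assay so far, at 1000 nM. The entry for compound 1 is a limit, > 100000 nM.

Among the measured compounds shown here, the single measured step, an at least 100-fold lower number from compound 1 to compound 2 (2.00 log units; beyond the scatter), is large. In it, 3-(diethylamino)propyl took the place of 1H-benzimidazol-2-yl.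

Compound 3 `COc1c(OCCCN2CCCC2)cc(O)c2c(=O)cc(-c3ccccc3)oc12` differs from compound 2 by a smaller exchange: pyrrolidin-1-yl in place of (diethylamino)methyl on a saturated chain carbon, three bonds along the chain from an oxygen on an aromatic ring. Here pyrrolidin-1-yl stands in place of (diethylamino)methyl on a saturated chain carbon, three bonds along the chain from an oxygen on an aromatic ring. Cut one bond further out, this reads 4-(diethylamino)butyl to 3-(pyrrolidin-1-yl)propyl.

For the measured compounds named here, no measured step tests this exchange directly. The chain end still carries a nitrogen, unlike the large swap in an at least 100-fold lower number from compound 1 to compound 2 (2.00 log units; beyond the scatter), so only a small change is expected, with no firm direction. The estimated step is a 1.5-fold higher number from compound 2 to compound 3 (0.18 log units; within the scatter). The expected value for compound 3 is 1500 nM, with an estimated range of 400 nM to 6000 nM.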

Compound 3, half-maximal inhibitory concentration: 1390 nM
Compound 3: middle estimate off by 1.1-fold (0.03 log units), on the high side; the range from low to high includes it.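

In this assay, replacing (diethylamino)methyl with pyrrolidin-1-yl, on a saturated chain carbon, three bonds along the chain from an oxygen on an aromatic ring, leaves the two compounds within the scatter of each other (a 1.4-fold higher number from compound 2 to compound 3 (0.14 log units; within the scatter)). This position therefore accepts a chain end with a five-membered non-aromatic ring as well as one with no ring, which compound 2 alone could not show. The large gap from the 1H-benzimidazol-2-yl compound now also appears with a second nitrogen-bearing chain end (an at least 71-fold lower number from compound 1 to compound 3 (1.85 log units; beyond the scatter)), although this step starts from a limit and not from a number: the limit of > 100000 nM in this assay, at which 1 of the 3 values shown sits.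

The same difference also reads as 4-(diethylamino)butyl to 3-(pyrrolidin-1-yl)propyl, so the chain and its end change together, and any separate effects of the two cannot be told apart. A 4-(pyrrolidin-1-yl)butyl chain would separate them, while a chain ending in a hydroxyl group would test whether the amine nitrogen is needed at all.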